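The compounds below may be only part of what the source reports. "The series", "measured", "known", "first", "only" and "open" are said of these compounds alone.

Measured compounds:
Compound 1, `CC(=O)c1cc(-c2ccc(F)cc2)cc2cc(-c3ccc(F)cc3)[nH]c12`, gives 13800 nM in a functional assay on HeLa cells (Homo sapiens) for cytotoxicity, read by MTT assay, with a stated time of 2 days; a lower number here means that less compound is tolerated, a higher number that more compound is tolerated.
Compound 2, `CC(=O)c1cc(/C=C/c2ccc(F)cc2)cc2cc(-c3ccccc3)[nH]c12`, gives 9260 nM in this assay.

Going by the values given here, compound 2 stands at the lowest of the two numbers, with compound 1 as its only neighbour; the two values lie within the scatter of each other, so neither compound can be called more or less tolerated than the other. Compound 3, `CC(=O)c1cc(/C=C/c2ccc(F)cc2)cc2cc(-c3ccc(F)cc3)[nH]c12`, is reached from compound 2 by one change: fluoro in place of hydrogen on an aromatic carbon. Among the compounds with values here, no pair of measured compounds differs in exactly this way, so there is no measured step to lean on. The two values shown sit close together despite larger structural differences between them, and a single fluoro in place of hydrogen on an aromatic carbon is expected to move the number little in this assay, in no particular direction beyond the scatter. Compound 3 is therefore estimated at 9500 nM, within 4500 nM to 20000 nM, which corresponds to an expected step of a 1.0-fold higher number from compound 2 to compound 3 (0.01 log units; within the scatter).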

Compound 3, concentration lethal to 50% of the cells: 5680 nM
For compound 3 the middle estimate is 1.7-fold (0.22 log units) above the measured one; measured number inside the range.
By their numbers in this assay, from the lowest: compounds 3, 2 and 1 (each within the scatter of the next, the first and the last beyond it).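

In this assay the change from phenyl to 4-fluorophenyl gives a 1.6-fold lower number from compound 2 to compound 3 (0.21 log units; within the scatter) and so does not separate these two compounds at this position, para to a large group. Placing 2-(4-fluorophenyl)ethenyl instead of 4-fluorophenyl on the aromatic carbon gives a 2.4-fold lower number from compound 1 to compound 3 (0.39 log units; beyond the scatter) and is the only modest step here that stands clear of the scatter, though this rests on a single pair. Nothing available explains either step. From the compounds shown here alone, whether chloro, methoxy or an amine in place of the fluoro would behave the same way remains open. Going by these compounds, it is also open whether a longer chain in place of the ethenyl link would shift the number further, and whether the ethenyl step would hold on other versions of the shared core.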